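Adding 4-fluorophenyl to a chain at the assay limit

The source may report more compounds than this note shows. Statements on the series, on what has been measured and on what is new or still open speak of the compounds shown alone.

Measured in a functional assay on SK-BR-3 cells (Homo sapiens) for antiproliferative activity, read by MTT assay, with a stated time of 72 h; on this read-out lower numbers stand for stronger inhibition and higher numbers for weaker inhibition:
- Compound 1 `C#CCOC(=O)C[C@@H]1C(C(=O)OC)=CO[C@@H](O[C@@H]2O[C@H](CO)[C@@H](O)[C@H](O)[C@H]2O)/C1=C/C` gives > 15000 nM as a limit
- Compound 2 `C/C=C1/[C@H](O[C@@H]2O[C@H](CO)[C@@H](O)[C@H](O)[C@H]2O)OC=C(C(=O)OC)[C@H]1CC(=O)OCCC` gives > 15000 nM as a limit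
- Compound 3 `C/C=C1/[C@H](O[C@@H]2O[C@H](CO)[C@@H](O)[C@H](O)[C@H]2O)OC=C(C(=O)OC)[C@H]1CC(=O)OCC` gives > 15000 nM as a limit

Compound 3 gives > 15000 nM as a limit and not as a number. It therefore has no rank among the three, and the whole set stands at one point: the limit of > 15000 nM in this assay, at which 3 of the 3 values shown sit.

Compound 4 `C/C=C1/[C@H](O[C@@H]2O[C@H](CO)[C@@H](O)[C@H](O)[C@H]2O)OC=C(C(=O)OC)[C@H]1CC(=O)OCCc1ccc(F)cc1` differs from compound 3 as follows: 4-fluorophenyl in place of hydrogen on a saturated chain carbon, two bonds along the chain from an oxygen next to a carbonyl group with 4-fluorophenyl in place of hydrogen on a saturated chain carbon, two bonds along the chain from an oxygen next to a carbonyl group.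

The measured steps that bear on this change all concern the same chain. They are a step that the two limits leave unreadable from compound 2 to compound 3 and a step that the two limits leave unreadable from compound 1 to compound 2 and also a step that the two limits leave unreadable from compound 1 to compound 3 with no size to read in any of them. They offer no direction of their own. With nothing else to go on, no step beyond the scatter is expected in this assay and a further limit is the likeliest report.

The estimated change is a step that the limit leaves unreadable from compound 3 to compound 4 and it is only an expectation. Compound 4 is expected near 20000 nM with an estimated range from 8000 nM to 40000 nM for its value.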

Compound 4, half-maximal inhibitory concentration: > 20000 nM
Compound 4 gave a limit, no number (the forecaster's own chance of this, stated with the estimate: 80%); the middle value lies on the limit itself.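

In this assay compound 4 gives > 20000 nM, which is a limit and not a number. Within the data shown here, compound 1, compound 2 and compound 3 also gave only limits, so no step from any of them to compound 4 can be read. The compounds shown leave open what actual value any of the four would reach in this assay, and whether their chains differ at all.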